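Nitro to Amino on Two Related Cores

This account rests on a few compounds, and the source may have more. Where it says the series, first, only, none or still open, it means among the compounds named here.

Measured compounds:
compound 1, `COc1ccc(NC(=O)c2cc(OC)c(OC)c(OC)c2)cc1[N+](=O)[O-]`, 2900 nM 
compound 2, `COc1ccc(NC(=O)c2cc(OC)c(OC)c(OC)c2)cc1N`, 2000 nM 
compound 3, `COc1ccc(C(=O)Oc2cc(OC)c(OC)c(OC)c2)cc1[N+](=O)[O-]`, 35200 nM 

In a functional assay on MDA-MB-468 cells (Homo sapiens) for antiproliferative activity, read by MTT assay, with a stated time of 72 h (on this read-out lower numbers stand for stronger inhibition and higher numbers for weaker inhibition), compound 1 gives 2900 nM and compound 2 gives 2000 nM. The change that separates them, (amino in place of nitro on an aromatic carbon), produced a 1.5-fold lower number from compound 1 to compound 2 (0.16 log units; within the scatter). Compound 3 stands highest of the three, and the difference between its core and that of compound 1 is not broken down here. Compound 4, `COc1ccc(C(=O)Oc2cc(OC)c(OC)c(OC)c2)cc1N`, has not been measured in this assay; it carries the same change as compound 2, (amino in place of nitro on an aromatic carbon), set on the core of compound 3. The step is expected to be a 1.4-fold lower number from compound 3 to compound 4 (0.15 log units; within the scatter), which rests on the step from compound 1 to compound 2, a 1.5-fold lower number from compound 1 to compound 2 (0.16 log units; within the scatter). Compound 4 is therefore estimated at 25000 nM, with a likely range from 10000 nM to 60000 nM.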

Compound 4, half-maximal inhibitory concentration: > 100000 nM
Compound 4 was reported as a limit (the forecaster's own chance of this, stated with the estimate: 10%); at least 4.0-fold (0.60 log units) between middle value and limit.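

Amino in place of nitro gives an at least 2.8-fold higher number from compound 3 to compound 4 (0.45 log units; beyond the scatter) in this assay, which does not repeat what the same change did on the core of compound 1: the same change on two cores in this assay, a 1.5-fold lower number (0.16 log units; within the scatter) from compound 1 to compound 2 and an at least 2.8-fold higher number (0.45 log units; beyond the scatter) from compound 3 to compound 4, at least 4.1-fold (0.61 log units) apart, beyond the scatter of two such steps

Compound 4 stands at > 100000 nM, which is a limit of the assay and not a number: the limit of > 100000 nM in this assay, at which 1 of the 4 values shown sits.

So, for these two pairs, the step on one core did not carry over to the other, but this does not show what in the cores sets the steps apart or how large the second step really is, and two pairs set no rule for the series.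

On these data alone, it remains open whether a hydroxyl or an acetamide group in the same place would also part the two cores. As far as these compounds go, whether a core other than these two would follow either step also remains open.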